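A few compounds are considered here, and "the series" means these few. Any claim that something is new, unique, unknown or untested is made for them only; others in the source may bear on it.

Of the compounds shown here, two have been tested for cytotoxicity in a functional assay on Molt4/C8 cells (Homo sapiens) for cytotoxicity; a higher number here means a weaker inhibitor, a lower number a stronger inhibitor. Compound 1, `Cc1cccc(C)c1NC(=O)/C=C/C(=O)N1C/C(=C\c2ccc([N+](=O)[O-])cc2)C(=O)/C(=C/c2ccc([N+](=O)[O-])cc2)C1`, gives 210 nM in this assay. Compound 2, `O=C(/C=C/C(=O)N1C/C(=C\c2ccccc2)C(=O)/C(=C/c2ccccc2)C1)Nc1ccc(Cl)cc1`, gives 1800 nM in this assay. Of these two numbers, compound 1 holds the lower one, and the gap to compound 2 lies beyond the usual scatter of this assay; compound 2 differs from compound 1 at more than one place, so no single change can be read off from that pair.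

Compound 3, `O=C(/C=C/C(=O)N1C/C(=C\c2ccc([N+](=O)[O-])cc2)C(=O)/C(=C/c2ccc([N+](=O)[O-])cc2)C1)Nc1ccccc1`, has not yet been measured. Compared with compound 1 the change is phenyl in place of 2,6-dimethylphenyl on an amide-type nitrogen. Going by the values given here, the only comparison on hand does not isolate this kind of change, so there is no measured step to lean on.

The expected step from compound 1 to compound 3 is a modest rise, at most slightly beyond the scatter, estimated as a 1.7-fold higher number from compound 1 to compound 3 (0.22 log units; within the scatter). On that basis compound 3 is estimated to give 350 nM in this assay, with a likely range from 120 nM to 1000 nM.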

Compound 3, half-maximal inhibitory concentration: 360 nM
Beside the measured number, compound 3's estimate is 1.0-fold (0.01 log units) below it; the range from low to high includes it.
By their numbers in this assay, from the lowest: compounds 1 and 3 (each within the scatter of the next); then compound 2.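

In this assay, going by these compounds alone, this is the first comparison that isolates a single change on the amide-type nitrogen: phenyl in place of 2,6-dimethylphenyl gives a 1.7-fold higher number from compound 1 to compound 3 (0.23 log units; within the scatter), so the two groups cannot be told apart in this pair. The two methyl groups are therefore not needed to keep this pair's cytotoxicity in the same range, as compound 3, which lacks them, gives 360 nM in this measurement. No accompanying data bear on why the two groups read alike.

Within the data shown here, this single pair covers only two closely related aromatic groups, so it remains unknown whether the same holds for a longer alkyl chain, an amine or a carboxylic acid-bearing group on the amide-type nitrogen. Compound 2 still differs from both compound 1 and compound 3 at more than one place, which leaves the separate contributions of its chloro group and of the nitro groups carried by compound 1 and compound 3 unresolved.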